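The source may hold more compounds than are shown below. What is called first, only, known or untested is meant among the compounds shown, and "the series" means these compounds.

Of the compounds shown here, three sharing one core have been tested in an assay on isolated protein with malate dehydrogenase, mitochondrial (Sus scrofa) as the target; a lower number here means a stronger inhibitor, a higher number a weaker inhibitor. Compound 1 `O=C(O)c1cnc2cc(F)ccc2c1O` gives 10500000 nM, the highest number of the three, so it is the weakest inhibitor among them. Compound 2 `O=C(O)c1cnc2cc(S(=O)(=O)O)ccc2c1O` gives 2140000 nM, and compound 3 `O=C(O)c1cnc2cc(OCCc3ccc(Br)cc3)ccc2c1O` gives 2510 nM, a far lower number than compound 1 shows.

Going by the values given here, the one step that can be traced between measured compounds is a 4.9-fold lower number from compound 1 to compound 2 (0.69 log units; beyond the scatter). Replacing the fluoro group with a sulfo group therefore brings the number down, though only modestly.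

Compound 4 `CC(=O)c1ccc2c(O)c(C(=O)O)cnc2c1` differs from compound 1 in the same position of the core: acetyl in place of fluoro on an aromatic carbon. Among the compounds with values here, no measured pair tests an acetyl group directly, so the expectation rests on the fact that the only measured exchange at this site, from compound 1 to compound 2, lowered the number modestly, while compound 3 shows that a much larger group at this position comes with a far lower number still. A modest lowering of the number is therefore expected, with a 3.5-fold lower number from compound 1 to compound 4 (0.54 log units; beyond the scatter) as the estimated step. Compound 4 is expected to give about 3000000 nM in this assay, somewhere between 700000 nM and 12000000 nM.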

Compound 4, half-maximal inhibitory concentration: 912000 nM
Compound 4: middle estimate off by 3.3-fold (0.52 log units), on the high side, within the range that was stated.
By their numbers in this assay, from the lowest: compound 3; then compound 4; then compound 2; then compound 1.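

In this assay, going by these compounds alone, acetyl in place of fluoro gives a 12-fold lower number from compound 1 to compound 4 (1.06 log units; beyond the scatter) and so moves the number further than the single earlier exchange at this position did. The comparison between the two replacement groups gives a 2.3-fold lower number from compound 2 to compound 4 (0.37 log units; beyond the scatter) and is beyond the scatter, so the result depends on which group enters and not merely on fluoro leaving. Acetyl adds only a few heavy atoms, yet this small exchange produces a large step, which shows that a big group like that of compound 3 is not needed for a clear drop in the number, although nothing here explains why acetyl outperforms sulfo.

Compound 3 still stands far lower at 2510 nM than compound 4 at 912000 nM, and no compound shown fills the wide gap between them, so a short ether such as methoxy or a longer chain ending in a plain phenyl ring could show how the number changes as the group grows. Going by these compounds, it also remains open whether an amine, an amide or a carboxylic acid at this position would match acetyl or fall closer to sulfo.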